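This account rests on a few compounds, and the source may have more. Where it says the series, first, only, none or still open, it means among the compounds named here.

In a functional assay on MCF7 cells (Homo sapiens) for antiproliferative activity, read by MTT assay (a higher number here means a weaker inhibitor, a lower number a stronger inhibitor), compound 1 `COc1cc2c(Oc3ccc(NC(=O)Nc4ccccc4Cl)cc3)ccnc2cc1OCCCCCCC(=O)NO` gives 2780 nM, compound 2 `COc1cc2c(Oc3ccc(NC(=O)Nc4cccc(C)c4)cc3)ccnc2cc1OCCCCCCC(=O)NO` gives 1240 nM and compound 3 `COc1cc2c(Oc3ccc(NC(=O)Nc4ccccc4C(F)(F)F)cc3)ccnc2cc1OCCCCCCC(=O)NO` gives 1080 nM. The value of compound 2 thus lies within the scatter of that of compound 3 and clear of that of compound 1. Compound 4 `COc1cc2c(Oc3ccc(NC(=O)Nc4ccccc4F)cc3)ccnc2cc1OCCCCCCC(=O)NO` has 2-fluorophenyl in place of 3-methylphenyl on an amide-type nitrogen. Going by the values given here, three steps bear on this change. There is a 2.2-fold lower number from compound 1 to compound 2 (0.35 log units; beyond the scatter), which lies beyond the scatter, and a 1.1-fold lower number from compound 2 to compound 3 (0.06 log units; within the scatter), which does not, while a 2.6-fold lower number from compound 1 to compound 3 (0.41 log units; beyond the scatter) separates the 2-chlorophenyl and 2-(trifluoromethyl)phenyl groups. These precedents disagree, so at most a modest rise is expected in this assay. The expected change is a 1.3-fold higher number from compound 2 to compound 4 (0.11 log units; within the scatter). Compound 4 is estimated at 1600 nM, with an expected range of 800 nM to 3200 nM.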

Compound 4, half-maximal inhibitory concentration: 660 nM
Compound 4: middle estimate off by 2.4-fold (0.38 log units), on the high side, outside the stated range (below it).
By their numbers in this assay, from the lowest: compounds 4, 3 and 2 (each within the scatter of the next); then compound 1.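

In this assay, 2-fluorophenyl on the amide-type nitrogen stays within the scatter of the groups in the two nearest compounds, with a 1.9-fold lower number from compound 2 to compound 4 (0.27 log units; within the scatter) and a 1.6-fold lower number from compound 3 to compound 4 (0.21 log units; within the scatter). Only the chloro group stands clear of fluoro on this aromatic carbon, with a 4.2-fold lower number from compound 1 to compound 4 (0.62 log units; beyond the scatter), so compound 1 alone sits apart from the other three. Nothing measured here accounts for that gap. The compounds shown leave open how a bromo group, an amine or a carboxylic acid on this phenyl ring would read in this assay.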